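The source may hold more compounds than are shown below. What is called first, only, known or untested is meant among the compounds shown, and "the series" means these compounds.

Compound 3 `CC1=C(C(=O)Nc2ccc([N+](=O)[O-])cc2)C(c2cccc([N+](=O)[O-])c2)N=C(SCc2ccccc2)N1` holds the lowest of the three numbers in a functional assay on the whole organism (artery, strain albino) with Rattus norvegicus as the target, with a stated time of 900 min, at a dose of 10 mg/kg by the oral route (on this read-out higher numbers stand for more inhibition at the one dose given (going by the name of the read-out) and lower numbers for less inhibition), where compound 3 gives 14.9%, though all three values lie within the scatter of one another: compound 1 `COc1ccc(C2N=C(SCc3ccc(F)cc3)NC(C)=C2C(=O)Nc2ccc(Br)cc2)cc1` gives 15.4% and compound 2 `CC1=C(C(=O)Nc2ccc([N+](=O)[O-])cc2)C(c2ccc(Br)cc2)N=C(SCc2ccccc2)N1` gives 19.5%. For the measured compounds named here, the only step measured between compounds differing in a single place, a number 4.6 percentage points lower from compound 2 to compound 3 (within the scatter), concerns another position and does not bear on the change at hand. Compound 4 `CC1=C(C(=O)Nc2ccc([N+](=O)[O-])cc2)C(c2cccc([N+](=O)[O-])c2)N=C(SCc2ccc(F)cc2)N1` differs from compound 3 by fluoro in place of hydrogen on an aromatic carbon. Compound 1 already carries the 4-fluorobenzyl group, although it differs from compound 3 elsewhere as well, and its value lies close to that of compound 3. With nothing pointing to movement, compound 4 is estimated at 15%, between 7% and 24%. The expected step of a number 0.1 percentage points higher from compound 3 to compound 4 (within the scatter) is therefore essentially flat.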

Compound 4, a percentage reported as inhibition, in the whole organism at one dose (the size of the read-out at that dose, not a potency): 15.4%
Compound 4: the middle estimate sits 0.4 percentage points below what was measured, within the range that was stated.
By their numbers in this assay, from the lowest: compounds 3, 1, 4 and 2 (each within the scatter of the next).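

In this assay, for the compounds shown here, the change from benzylsulfanyl to (4-fluorobenzyl)sulfanyl gives a number 0.5 percentage points higher from compound 3 to compound 4 (within the scatter) and is the only direct reading at this position. A single fluoro here does not separate the two compounds, something compound 1 could only hint at since it differs in other places too. Nothing at hand speaks to why they read alike. From the compounds shown here alone, whether a larger group at this place, such as methoxy, trifluoromethyl or an amine, would move the number stays open. So does whether fluoro reads the same alongside other groups on the shared core.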